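The compounds below may be only part of what the source reports. "The series", "measured", "known", "first", "only" and "open" are said of these compounds alone.

Measured in a functional assay on AGS cells (Homo sapiens) for antiproliferative activity, read by CCK-8 assay, with a stated time of 72 h; on this read-out higher numbers stand for weaker inhibition and lower numbers for stronger inhibition:
compound 1 `CC(=O)N1CC=C(c2ccn3c(-c4ccc(NC(=O)c5ccc([N+](=O)[O-])o5)cc4)cnc3c2)CC1` gives 410 nM
compound 2 `O=C(Nc1ccc(-c2cnc3cc(N4CCN(C5CC5)CC4)ccn23)cc1)c1ccc([N+](=O)[O-])o1` gives 1920 nM
compound 3 `O=C(Nc1ccc(-c2cnc3cc(C4=CCN(C5COC5)CC4)ccn23)cc1)c1ccc([N+](=O)[O-])o1` gives 790 nM

Compound 3 stands second highest of the three numbers. Its nearest neighbour is compound 1, with a 1.9-fold higher number from compound 1 to compound 3 (0.28 log units; within the scatter); its furthest is compound 2, with a 2.4-fold lower number from compound 2 to compound 3 (0.39 log units; beyond the scatter).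

Compound 4 `O=C(Nc1ccc(-c2cnc3cc(N4CCCC4)ccn23)cc1)c1ccc([N+](=O)[O-])o1` differs from compound 3 in one place: a group of 5 heavy atoms (4 carbon, 1 nitrogen; one five-membered non-aromatic ring with 1 hetero atom) in place of a group of 10 heavy atoms (8 carbon, 1 nitrogen, 1 oxygen; one four-membered non-aromatic ring with 1 hetero atom, one six-membered non-aromatic ring with 1 hetero atom), on an aromatic carbon. For the measured compounds named here, no measured pair makes exactly this exchange. Going by the values given here, the steps that bear on it are the two that swap the entire substituent at the same aromatic carbon, namely a 4.7-fold higher number from compound 1 to compound 2 (0.67 log units; beyond the scatter) and a 2.4-fold lower number from compound 2 to compound 3 (0.39 log units; beyond the scatter). In both, the substituent with a six-membered non-aromatic ring with 2 hetero atoms, joined through nitrogen as pyrrolidin-1-yl is, carried the higher number against either six-membered ring with 1 hetero atom. On that basis a modest rise in the number is expected for compound 4, a 2.5-fold higher number from compound 3 to compound 4 (0.40 log units; beyond the scatter). Compound 4 is therefore estimated at 2000 nM, with an expected range of 600 nM to 6500 nM.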

Compound 4, half-maximal inhibitory concentration: 1240 nM
For compound 4 the middle estimate is 1.6-fold (0.21 log units) above the measured one, and the stated range covers the measured number.
By their numbers in this assay, from the lowest: compounds 1, 3, 4 and 2 (each within the scatter of the next, the first and the last beyond it).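

Working from this assay, the smaller pyrrolidin-1-yl at this aromatic carbon, opposite the ring nitrogen, cannot be told apart from 4-cyclopropylpiperazin-1-yl (a 1.5-fold lower number from compound 2 to compound 4 (0.19 log units; within the scatter)) or from the oxetan-3-yl-bearing group of compound 3 (a 1.6-fold higher number from compound 3 to compound 4 (0.20 log units; within the scatter)), although those two larger groups do differ from each other beyond the scatter. Only the acetyl-bearing group of compound 1 stays clearly apart (a 3.0-fold higher number from compound 1 to compound 4 (0.48 log units; beyond the scatter)), so joining through nitrogen does not cleanly separate the groups here, and compound 3, joined through carbon, goes against any such split. Nothing at hand accounts for these steps.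

Still open, as far as these compounds go, is how an open-chain dimethylamino group or a morpholin-4-yl group would read at this carbon. Also open, from the compounds shown here alone, is how the six-membered ring of compound 1 would read with a free secondary amine in place of acetyl.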